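This account rests on a few compounds, and the source may have more. Where it says the series, first, only, none or still open, it means among the compounds named here.

Measured compounds:
compound 1, `C=CC[C@H]1C[C@]2([C@H](C)Cc3ccc(OC)c(OC)c3)OCOC2=CC1=O`, 320 nM
compound 2, `C=CC[C@H]1C[C@]2([C@H](C)Cc3ccc(OC)cc3)OCOC2=CC1=O`, 120 nM
compound 3, `C=CC[C@H]1C[C@]2([C@@H](C)Cc3cccc(OC)c3)OCOC2=CC1=O`, 10600 nM

All three were tested in a functional assay on NCI-H460 cells (Homo sapiens) for antiproliferative activity, with a stated time of 72 h; a lower number here means a stronger inhibitor, a higher number a weaker inhibitor. Compound 1 and compound 2 share a core and differ in one place: hydrogen in place of methoxy on an aromatic carbon. That change gave a 2.7-fold lower number from compound 1 to compound 2 (0.43 log units; beyond the scatter), so removing this methoxy made the compound a somewhat stronger inhibitor. Compound 3 stands apart, giving the highest number of the three; the difference between the core of compound 3 and the core of compound 1 is not broken down here, so the two compounds are compared only through their values.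

Compound 4, `C=CC[C@H]1C[C@]2([C@@H](C)Cc3ccccc3)OCOC2=CC1=O`, has not been measured yet. It differs from compound 3 in one place: hydrogen in place of methoxy on an aromatic carbon. For the measured compounds named here, this is the same kind of change as the one from compound 1 to compound 2, though the surroundings are not identical: in the earlier pair the methoxy that leaves sits ortho to a methoxy group, whereas in compound 3 no second methoxy is present on that ring. Given that the earlier pair showed a 2.7-fold lower number from compound 1 to compound 2 (0.43 log units; beyond the scatter), a step of similar, modest size is expected here, and compound 4 is estimated to give 4500 nM in this assay, somewhere between 1500 nM and 15000 nM, which means an expected step of a 2.4-fold lower number from compound 3 to compound 4 (0.37 log units; beyond the scatter). Because compound 3 gave 10600 nM, compound 4 is still expected to be a weak inhibitor compared with compound 1 and compound 2.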

Compound 4, half-maximal inhibitory concentration: 9700 nM
The estimate for compound 4 lay 2.2-fold (0.33 log units) below the measured number; the measured number falls inside the stated range.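

In this assay, putting hydrogen in place of methoxy, which turns 3-methoxyphenyl into phenyl, gave a 1.1-fold lower number from compound 3 to compound 4 (0.04 log units; within the scatter), so on this core the change made no difference that can be told from ordinary repeat variation. Set beside the step on the other core, this gives no firm sign that the outcome of the change depends on the core: the same change on two cores in this assay, a 2.7-fold lower number (0.43 log units; beyond the scatter) from compound 1 to compound 2 and a 1.1-fold lower number (0.04 log units; within the scatter) from compound 3 to compound 4, 2.4-fold (0.39 log units) apart, within the scatter of two such steps. For the compounds shown here, it does not show that the change carries over with a fixed size either: there are only two pairs, one step lies beyond the scatter and the other within it, and two pairs cannot say whether any feature of the cores sets the size of the step.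

The compounds shown leave open whether a hydroxyl group, a fluorine atom or an amine in place of that methoxy would shift the number on either core. They also leave open whether both cores would answer alike to such groups, which a matched pair on each core would be needed to test.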